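Swapping Phenyl for a Halogenated Ring on the Core

This account rests on a few compounds, and the source may have more. Where it says the series, first, only, none or still open, it means among the compounds named here.

Compound 1 `O=C(Nc1ccc(Oc2ccnc3[nH]ccc23)cc1)c1cc2cccnc2n(-c2ccccc2)c1=O` and compound 2 `Cn1ccc2c(Oc3ccc(NC(=O)c4cc5cccnc5n(-c5ccccc5)c4=O)cc3)ccnc21` share one core. In a functional assay on HT-29 cells (Homo sapiens) for antiproliferative activity, read by MTT assay, with a stated time of 72 h (a higher number here means a weaker inhibitor, a lower number a stronger inhibitor), compound 1 gives 290 nM and compound 2 gives 620 nM; the step of a 2.1-fold higher number from compound 1 to compound 2 (0.33 log units; beyond the scatter) leaves the latter as the higher of the two numbers. Compound 3 `Cn1ccc2c(Oc3ccc(NC(=O)c4cc5cccnc5n(-c5ccc(F)c(Cl)c5)c4=O)cc3)ccnc21` differs from compound 2 by 3-chloro-4-fluorophenyl in place of phenyl on an aromatic nitrogen. Among the measured compounds shown here, no measured step touches this ring, so the single earlier step gives no guidance on direction or size. The step from compound 2 to compound 3 is therefore expected to be a 1.2-fold lower number from compound 2 to compound 3 (0.09 log units; within the scatter), within the scatter. Compound 3 is estimated at 500 nM, between 150 nM and 1800 nM.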

Compound 3, half-maximal inhibitory concentration: 1210 nM
Compound 3: the middle estimate sits 2.4-fold (0.38 log units) below what was measured; low and high end bracket the measured number.
By their numbers in this assay, from the lowest: compound 1; then compounds 2 and 3 (each within the scatter of the next).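

In this assay, 3-chloro-4-fluorophenyl in place of phenyl on the aromatic nitrogen gives a 2.0-fold higher number from compound 2 to compound 3 (0.29 log units; within the scatter). Among the compounds shown here, this is the first reading at this position, and it shows that adding the chlorine and fluorine to this ring leaves the two compounds within the usual scatter of each other. No measurement here bears on why this is so.

The compounds shown leave open how a methoxy group or an amine on this ring would read. As far as these compounds go, it also remains open whether chlorine or fluorine alone would read the same as the pair.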